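The compounds below may be only part of what the source reports. "The series", "measured", "known", "first", "only" and "open" are said of these compounds alone.

Compound 2 `C[C@@H]1CN(c2sc(C(F)(F)F)nc2-c2nc3ccccc3[nH]2)CCN1C(=O)Cn1cccn1` gives 191 nM in a functional assay on Venous blood for antagonist activity at C-X-C chemokine receptor type 3 (Homo sapiens), read by flow cytometry, with a stated time of 30 min, in the presence of a further agent that is not named here (a higher number here means a weaker inhibitor, a lower number a stronger inhibitor), the lowest number among the three measured here. Compound 1 `Cc1nc(C)n(CC(=O)N2CCN(c3sc(C(F)(F)F)nc3-c3nc4c(F)cccc4[nH]3)C[C@H]2C)n1` gives 321 nM in this assay, which lies within the scatter of compound 2. Compound 3 `C[C@@H]1CN(c2sc(C(F)(F)F)nc2-c2nc3ccccc3n2C)CCN1C(=O)Cn1cccn1` gives 3560 nM in this assay, and the step of a 19-fold higher number from compound 2 to compound 3 (1.27 log units; beyond the scatter) goes with methyl in place of hydrogen on an aromatic nitrogen. Compound 4 `C[C@@H]1CN(c2sc(C(F)(F)F)nc2-c2nc3ccccc3[nH]2)CCN1C(=O)Cn1cc(C2CCN(C)CC2)cn1` differs from compound 2 by 1-methylpiperidin-4-yl in place of hydrogen on an aromatic carbon. For the measured compounds named here, the only measured step, a 19-fold higher number from compound 2 to compound 3 (1.27 log units; beyond the scatter), concerns a different ring and a different kind of change, so it does not bear on this one. The expected step is a 1.2-fold lower number from compound 2 to compound 4 (0.08 log units; within the scatter), which is no change beyond the scatter. Compound 4 is therefore estimated at 160 nM, in a range from 50 nM to 500 nM.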

Compound 4, half-maximal inhibitory concentration: 1690 nM
Beside the measured number, compound 4's estimate is 11-fold (1.02 log units) below it; measured number above the stated range.
By their numbers in this assay, from the lowest: compounds 2 and 1 (each within the scatter of the next); then compound 4; then compound 3.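

In this assay, the aromatic carbon of the five-membered aromatic ring with 2 nitrogen does not tolerate every group: 1-methylpiperidin-4-yl in place of hydrogen gives an 8.8-fold higher number from compound 2 to compound 4 (0.95 log units; beyond the scatter). So the part of the molecule beyond the amide carbonyl also affects the number, which the earlier compounds did not show at this carbon. No evidence here accounts for this step.

On these data alone, it remains open whether the step belongs to the whole 1-methylpiperidin-4-yl group or to its ring nitrogen. A cyclohexyl ring or a plain methyl at this carbon would separate the two.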